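A Methylfuran in Place of a Pyrrole

The source may report more compounds than this note shows. Statements on the series, on what has been measured and on what is new or still open speak of the compounds shown alone.

Compound 1 `O=C1NCCC12CCN(c1c(Cl)cncc1-c1ccco1)CC2` gives 940 nM here
Compound 2 `O=C1NCCC12CCN(c1c(Cl)cncc1-c1cc[nH]c1)CC2` gives 1050 nM here

Both numbers come from a functional assay on MV4-11 cells (Homo sapiens) for inhibition, read by resazurin assay, with a stated time of 72 h (a higher number here means a weaker inhibitor of growth, a lower number a stronger inhibitor of growth), and compound 2 stands level with compound 1 within the scatter. Going by the values given here, the only measured step is a 1.1-fold higher number from compound 1 to compound 2 (0.05 log units; within the scatter) and it is small, lying within the scatter, for furan-2-yl replaced by 1H-pyrrol-3-yl. Compound 3 `Cc1ccc(-c2cncc(Cl)c2N2CCC3(CCNC3=O)CC2)o1` carries 5-methylfuran-2-yl in place of 1H-pyrrol-3-yl on an aromatic carbon in this comparison. Among the compounds with values here, that measured step covers the swap of ring only, and no measured compound shows what the added methyl does. So no step beyond the scatter is expected in this assay for this change, though this expectation is uncertain. The estimated step is a 1.2-fold lower number from compound 2 to compound 3 (0.07 log units; within the scatter) and this lies within the scatter. Compound 3 is estimated at 900 nM with an expected range from 400 nM to 2000 nM in this measurement.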

Compound 3, concentration for 50% growth inhibition: 4950 nM
Compound 3: the middle estimate sits 5.5-fold (0.74 log units) below what was measured; measured number above the stated range.
By their numbers in this assay, from the lowest: compounds 1 and 2 (each within the scatter of the next); then compound 3.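

The earlier step showed only that furan-2-yl and 1H-pyrrol-3-yl sit level in this assay, and it said nothing about adding to the ring at this position. Methyl in place of hydrogen on the furan, the only change here, gives a 5.3-fold higher number from compound 1 to compound 3 (0.72 log units; beyond the scatter) and so makes growth inhibition weaker, while 5-methylfuran-2-yl in place of 1H-pyrrol-3-yl gives a similar a 4.7-fold higher number from compound 2 to compound 3 (0.67 log units; beyond the scatter) in the same direction. Thus this position accepted either unsubstituted ring, but not the methylated furan, and no measurement at hand accounts for this.

The compounds shown leave open whether the loss is particular to methyl or would also follow from an ethyl, a methoxy or an aminomethyl group in its place. Also open, on these data alone, is whether a methyl on the 1H-pyrrol-3-yl ring would weaken growth inhibition in the same way.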